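Small swaps, large jumps at one ring position

The source may report more compounds than this note shows. Statements on the series, on what has been measured and on what is new or still open speak of the compounds shown alone.

Compound 1 `CCC1=C(O)c2c(oc(-c3ccc(CC)cc3)cc2=O)C(CC)(CC)C1=O`: 0.07 uM
Compound 2 `CCC1=C(O)c2c(oc(-c3ccc(CC(C)C)cc3)cc2=O)C(CC)(CC)C1=O`: 17.4 uM
Compound 3 `CCC1=C(O)c2c(oc(-c3ccc(O)cc3)cc2=O)C(CC)(CC)C1=O`: 20.6 uM

These three values come from a functional assay on KBVIN cells (Homo sapiens) for antiproliferative activity, read by sulforhodamine B assay, with a stated time of 3 days; on this read-out lower numbers stand for an effect already at smaller amounts and higher numbers for an effect only at larger amounts of compound. Compound 2 sits at the high end of the numbers, level with compound 3, the gap being a 1.2-fold higher number from compound 2 to compound 3 (0.07 log units; within the scatter). Compound 1 stands well apart, with a 250-fold higher number from compound 1 to compound 2 (2.40 log units; beyond the scatter).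

The next structure is compound 4 `CCC1=C(O)c2c(oc(-c3ccc(OC(F)(F)F)cc3)cc2=O)C(CC)(CC)C1=O`. It keeps the shared core and carries trifluoromethoxy in place of isobutyl on an aromatic carbon.

The measured steps that bear on this change all concern the same group on the aromatic ring. One is the step already given, and the other is a 290-fold higher number from compound 1 to compound 3 (2.47 log units; beyond the scatter). Both are large, so among these three compounds a modest swap at this place can move the number a long way. Among the measured compounds shown here, neither step shows where trifluoromethoxy will fall, as no compound with this group has been measured. With compound 2 at 17.4 uM, close to the top of the measured range, a drop looks more likely than a rise, though a result near compound 2 remains possible.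

The expected step is a 5.8-fold lower number from compound 2 to compound 4 (0.76 log units; beyond the scatter). For compound 4, the estimated value in this assay is 3 uM, with an expected range from 0.3 uM to 25 uM.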

Compound 4, concentration for half-maximal effect: 9.95 uM
For compound 4 the middle estimate is 3.3-fold (0.52 log units) below the measured one; the measured number falls inside the stated range.
By their numbers in this assay, from the lowest: compound 1; then compounds 4, 2 and 3 (each within the scatter of the next, the first and the last beyond it).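

In this assay, putting trifluoromethoxy in place of isobutyl on this aromatic carbon gives a 1.7-fold lower number from compound 2 to compound 4 (0.24 log units; within the scatter), so two groups with quite different atoms give numbers that cannot be told apart. Replacing the hydrogen on the oxygen of the hydroxy group with trifluoromethyl gives a 2.1-fold lower number from compound 3 to compound 4 (0.32 log units; beyond the scatter), a modest shift that is small beside the large jump seen from the ethyl compound. That jump returns in a 140-fold higher number from compound 1 to compound 4 (2.15 log units; beyond the scatter), so isobutyl, hydroxy and trifluoromethoxy now all give numbers far higher than ethyl does, and among these four compounds ethyl alone gives a low number.

The compounds shown leave open whether the low number belongs to ethyl alone or extends to close relatives such as a methyl group or a straight propyl chain. They also leave open how an amine or a carboxylic acid on the same aromatic carbon would compare with these values.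

Nothing in the material given explains why the numbers fall this way.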